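A few compounds are considered here, and "the series" means these few. Any claim that something is new, unique, unknown or untested is made for them only; others in the source may bear on it.

Compound 3 `O=S(=O)(Nc1ccncn1)c1ccc2c(c1)OCC[C@@H]2c1ccc(C(F)(F)F)cc1-c1ccc(F)cn1` stands second of three in a physicochemical assay for solubility (a higher number here means a more soluble compound, a lower number a less soluble compound), at 181000 nM, with compound 2 `Cn1nccc1-c1cc(C(F)(F)F)ccc1[C@H]1CCOc2cc(S(=O)(=O)Nc3cccnn3)ccc21` first at 915000 nM and compound 1 `Cn1nccc1-c1cc(C(F)(F)F)ccc1[C@H]1CCOc2cc(S(=O)(=O)Nc3cccc(F)n3)ccc21` last at 27000 nM. Compound 4 `Cn1nccc1-c1cc(C(F)(F)F)ccc1[C@H]1CCOc2cc(S(=O)(=O)Nc3ccncn3)ccc21` keeps the sulfonamide substituent of compound 3 and carries 1-methyl-1H-pyrazol-5-yl in place of 5-fluoropyridin-2-yl on an aromatic carbon. Among the compounds with values here, no measured step covers this swap. The only one, a 34-fold higher number from compound 1 to compound 2 (1.53 log units; beyond the scatter), is large but lies on a sulfonamide nitrogen, with 1-methyl-1H-pyrazol-5-yl held constant, so it bears only indirectly and argues for a wide range. A modest upward step in this assay is expected, a 2.2-fold higher number from compound 3 to compound 4 (0.34 log units; beyond the scatter). For compound 4 the estimate is 400000 nM, with an expected range of 120000 nM to 1200000 nM.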

Compound 4, solubility: 1180000 nM
Compound 4: middle estimate off by 3.0-fold (0.47 log units), on the low side; measured number inside the range.
By their numbers in this assay, from the lowest: compound 1; then compound 3; then compounds 2 and 4 (each within the scatter of the next).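

In this assay, 1-methyl-1H-pyrazol-5-yl in place of 5-fluoropyridin-2-yl on an aromatic carbon gives a 6.5-fold higher number from compound 3 to compound 4 (0.81 log units; beyond the scatter), so this place also moves the read-out, not only the sulfonamide nitrogen. With 1-methyl-1H-pyrazol-5-yl held constant, pyrimidin-4-yl in place of pyridazin-3-yl gives a 1.3-fold higher number from compound 2 to compound 4 (0.11 log units; within the scatter), whereas pyrimidin-4-yl in place of 6-fluoropyridin-2-yl gives a 44-fold higher number from compound 1 to compound 4 (1.64 log units; beyond the scatter). Nothing available explains these steps.

Open, on these data alone, is whether the step on this aromatic carbon holds with pyridazin-3-yl or 6-fluoropyridin-2-yl on the sulfonamide nitrogen. Also open, as far as these compounds go, is how an amine or a carboxylic acid on this carbon would read.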